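Series notes: amine replacement on the core of compound 1

This account rests on a few compounds, and the source may have more. Where it says the series, first, only, none or still open, it means among the compounds named here.

Measured so far:
- compound 1, `CNc1nc(NCc2ccc(NC(=O)c3ccncc3)cc2)c2ccccc2n1`: in a functional assay on SW480 cells (Homo sapiens) for inhibition, read by luminescence and resazurin assay, with a stated time of 3 days (a lower number here means a stronger inhibitor, a higher number a weaker inhibitor), compound 1 is reported only as a limit, > 20000 nM.
- compound 2, `C=CCNc1nc(NCc2ccc(C(=O)Nc3ccc(F)cc3)cc2)c2cc(C)ccc2n1`: in this assay compound 2 gives 10000 nM.
- compound 3, `CNc1nc(NCc2ccc(NS(=O)(=O)c3ccc(F)cc3)cc2)c2ccccc2n1`: in this assay compound 3 gives 4800 nM.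

Compound 1 therefore has no number of its own in this assay, only (the limit of > 20000 nM in this assay, at which 1 of the 3 values shown sits). Within the data shown here, the one measured step within the set, an at least 4.1-fold lower number from compound 1 to compound 3 (0.61 log units; beyond the scatter), concerns the group on the aromatic nitrogen of the benzylic arm and not the core, so it gives no direct guide to the change considered here.

The next compound, compound 4, `CN1CCN(c2nc(NCc3ccc(NC(=O)c4ccncc4)cc3)c3ccccc3n2)CC1`, differs from compound 1 in one place: 4-methylpiperazin-1-yl in place of methylamino on an aromatic carbon. Among the measured compounds shown here, no measured pair in this set alters this position, so no step bears on it, and the expectation can rest only on where compound 1 stands, which is the limit (the limit of > 20000 nM in this assay, at which 1 of the 3 values shown sits). Because compound 1 sits at the limit of > 20000 nM in this assay, at which 1 of the 3 values shown sits, any change at this position is expected to be read against a limit rather than a number, and the step of an at least 1.3-fold lower number from compound 1 to compound 4 (0.12 log units; that floor lies within the scatter) is expected to be small or not resolvable. The estimate for compound 4 in this assay is 15000 nM, with a range from 4000 nM to 40000 nM.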

Compound 4, half-maximal inhibitory concentration: > 20000 nM
Compound 4 ended at the assay's limit (the forecaster's own chance of this, stated with the estimate: 50%); at least 1.3-fold (0.12 log units) between middle value and limit.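

In this assay compound 4 is reported only as a limit, > 20000 nM. Compound 1 is also reported only as a limit, > 20000 nM. Among these compounds, with a limit on both sides, no step between compound 1 and compound 4 can be read. On these data alone, whether 4-methylpiperazin-1-yl in place of methylamino on the shared core changes the number in this assay stays open.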